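Three Limits and a Hydroxyphenyl Sulfonamide

A few compounds are considered here, and "the series" means these few. Any claim that something is new, unique, unknown or untested is made for them only; others in the source may bear on it.

Compound 1 `COc1ccc(S(=O)(=O)Nc2ccc(-c3nc4ccccc4o3)cc2)cc1` in an assay on isolated protein for inhibition of malate dehydrogenase, mitochondrial (Sus scrofa), with stated times of 45 min and 30 min (a higher number here means a weaker inhibitor, a lower number a stronger inhibitor), gives only a limit, > 63000 nM.
Compound 2 `Cc1ccccc1S(=O)(=O)Nc1ccc2oc(-c3ccccc3)nc2c1` gives only a limit, > 63000 nM.
Compound 3 `O=S(=O)(Nc1ccc(-c2nc3ccccc3o2)cc1)c1ccccc1F` gives only a limit, > 63000 nM.

Compound 2 therefore stands where every measured compound stands, at the limit of > 63000 nM in this assay, at which 3 of the 3 values shown sit; no number is known for it. The change to compound 4 `O=S(=O)(Nc1ccc2oc(-c3ccccc3)nc2c1)c1cccc(O)c1` is 3-hydroxyphenyl in place of 2-methylphenyl on a sulfonyl sulfur. The only single-place step among measured compounds, a step that the two limits leave unreadable from compound 1 to compound 3, gives no readable size, so nothing shown says how a change on the sulfonyl sulfur shifts inhibition. The expected step that the limit leaves unreadable from compound 2 to compound 4 is therefore one of no change beyond the scatter, most likely leaving compound 4 again at the limit. Compound 4 is estimated at 90000 nM, in a range from 25000 nM to 400000 nM.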

Compound 4, half-maximal inhibitory concentration: > 63000 nM
Compound 4 ended at the assay's limit; the forecaster's own chance of this, stated with the estimate: 85%; the middle value lies beyond the limit too.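

No step can be read from compound 2 to compound 4: each gives only a limit of the assay, not a number. The compounds shown leave open whether any change on the sulfonyl sulfur shifts inhibition in this assay at all.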